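This account rests on a few compounds, and the source may have more. Where it says the series, first, only, none or still open, it means among the compounds named here.

Working notes on the series. Compound 1 `COc1ccc(/C=C/C(=O)Nc2cc3c(Nc4ccc(F)c(Cl)c4)ncnc3cc2OC)c(OC)c1` and compound 3 `COc1cc(/C=C/C(=O)Nc2cc3c(Nc4ccc(F)c(Cl)c4)ncnc3cc2O[C@H]2CCOC2)cc(OC)c1` share the core of compound 2 `COc1cc(/C=C/C(=O)Nc2cc3c(Nc4ccc(F)c(Cl)c4)ncnc3cc2OC)cc(OC)c1`; in a functional assay on PC-3 cells (Homo sapiens) for cytotoxicity, read by MTT assay, with a stated time of 72 h (a lower number here means a stronger inhibitor, a higher number a weaker inhibitor), compound 1 gives 38500 nM, and compound 3 gives 25600 nM. Compound 2 stands apart: in this assay compound 2 is reported as "not active" (no number reported), with no number given, so it has no single value to place against the other two. Compound 4 `COc1cc2ncnc(Nc3ccc(F)c(Cl)c3)c2cc1NC(=O)/C=C/c1ccc(C#N)cc1` differs from compound 2 in one place: 4-cyanophenyl in place of 3,5-dimethoxyphenyl on a double-bonded chain carbon bound to a double-bonded chain carbon. For the measured compounds named here, no measured step covers this change, so its direction cannot be read from the present data; given the weak numbers of compound 1 and compound 3 and the inactivity of compound 2, only a weak inhibitor is expected, and a limit rather than a number is a real possibility. Compound 4 is estimated in this assay at 30000 nM, with a range from 8000 nM to 100000 nM.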

Compound 4, half-maximal inhibitory concentration: "not active" (no number reported)
Compound 4: no number reported; there is nothing to compare the estimate with.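

No new step can be read between compound 2 and compound 4: neither has a number in this assay, and no evidence on this result is available. As far as these compounds go, whether 4-cyanophenyl in place of 3,5-dimethoxyphenyl changes potency remains open.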